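Swapping an Amino Group for tert-Butyl on a Shared Core

The compounds below may be only part of what the source reports. "The series", "measured", "known", "first", "only" and "open" are said of these compounds alone.

Compound 2 `Nc1ccc(-n2c(-c3cccnc3N)nc3cccnc32)cc1` sits at the bottom of the three measured compounds. In an in vitro assay on Sf9 cells for binding affinity to RAC-alpha serine/threonine-protein kinase (Homo sapiens), tested at 30 uM (a higher number here means that the compound stabilises the target more against heat, a lower number that the compound stabilises the target less), compound 2 gives 4.1 degrees C. Compound 1 `Nc1ncccc1-c1nc2cccnc2n1-c1ccc(NC(=O)c2ccccc2)cc1` gives 7.3 degrees C in this assay, and compound 3 `Nc1ncccc1-c1nc2cc(-c3cccnc3)cnc2n1-c1ccc(CNC(=O)c2ccccc2)cc1` gives 9.2 degrees C; both stand beyond the scatter above compound 2. Within the data shown here, the one single-point step recorded, a number 3.2 degrees C lower from compound 1 to compound 2 (beyond the scatter), comes from hydrogen in place of benzoyl on a nitrogen on an aromatic ring, so stripping that group lowered the shift modestly. Among the measured compounds shown here, compound 3 differs from compound 1 in more than one place and no step is drawn to it.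

Compound 4 `CC(C)(C)c1ccc(-n2c(-c3cccnc3N)nc3cccnc32)cc1` is the compound still to be measured. It differs from compound 2 by tert-butyl in place of amino on an aromatic carbon, on an aromatic carbon of a six-membered aromatic ring of carbon only, para to a large group. The step from compound 1 to compound 2 indicates that a larger substituent at this end of the molecule went with a higher melting-temperature shift, though that substituent carried a carbonyl whereas tert-butyl carries no hydrogen-bond donor or acceptor. For the measured compounds named here, no measured compound bears an alkyl group here, so the bearing is indirect. A modest rise is expected, a number 1.4 degrees C higher from compound 2 to compound 4 (beyond the scatter). Compound 4 is therefore estimated at 5.5 degrees C, within a range from 3.5 degrees C to 7.5 degrees C.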

Compound 4, shift of the target's melting temperature: 1.9 degrees C
Estimate against measurement, compound 4: 3.6 degrees C above; measured number below the stated range.
By their numbers in this assay, from the lowest: compound 4; then compound 2; then compound 1; then compound 3.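

In this assay, the change from amino to tert-butyl gives a number 2.2 degrees C lower from compound 2 to compound 4 (beyond the scatter), so a group with more heavy atoms at this position does not by itself go with a higher melting-temperature shift. Benzamido in place of tert-butyl marks the widest gap among the single-place changes, read in the other direction as a number 5.4 degrees C lower from compound 1 to compound 4 (beyond the scatter), and amino, with the fewest heavy atoms of the three groups, falls between them, so heavy-atom count does not set the order of compound 1, compound 2 and compound 4. No information is available here to explain why the number falls with tert-butyl.

Amino brings a hydrogen-bond donor and acceptor and tert-butyl brings neither, yet this single change alters the heavy atoms as well, so the compounds shown do not separate the two differences. Going by these compounds, how a hydroxyl or a dimethylamino group would stand at this position on the shared core, and whether a methyl group would fall as low as tert-butyl, remains open.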